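A few compounds are considered here, and "the series" means these few. Any claim that something is new, unique, unknown or untested is made for them only; others in the source may bear on it.

Measured in an ADME assay (liver) for metabolic stability, with Liver microsome (Rattus norvegicus) as the target, using microsomes and NADPH, with a stated time of 30 min, at 37 degrees C, tested at 1 uM; on this read-out higher numbers stand for fast clearance and lower numbers for slow clearance:

- Compound 1 `CC(O)(c1ccc(-c2ccc(S(=O)(=O)c3ccc(N)nc3)cc2)cc1)C(F)(F)F`: < 14 mL.min-1.g-1
- Compound 2 `Nc1ccc(S(=O)(=O)c2ccc(-c3ncc(C(O)(C(F)(F)F)C(F)(F)F)cn3)cc2)cn1`: < 14 mL.min-1.g-1
- Compound 3 `COc1cc(C(O)(C(F)(F)F)C(F)(F)F)cnc1-c1ccc(S(=O)(=O)c2ccc(N)nc2)cc1`: < 14 mL.min-1.g-1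

Each of these entries is a limit of the assay and not a measured number. Compound 3 gives < 14 mL.min-1.g-1, and this too is only a limit. The other two compounds stand in the same place, as the limit of < 14 mL.min-1.g-1 in this assay, at which 3 of the 3 values shown sit, shows, so the three cannot be put in any order. Among the measured compounds shown here, no pair of them differs in one place alone, which leaves no measured step to use as a guide.

Compound 4 `C[C@H](O)C#Cc1cc(C(O)(C(F)(F)F)C(F)(F)F)cnc1-c1ccc(S(=O)(=O)c2ccc(N)nc2)cc1` keeps the rest of compound 3 but has 3-hydroxybut-1-yn-1-yl in place of methoxy on an aromatic carbon. The new group is larger and brings a defined stereocentre. For the measured compounds named here, with no step to scale from, the expectation is cautious: little or no change beyond the usual scatter, and if a change does show, a modest rise in clearance. The result may well be a limit again. The expected step is a number no lower from compound 3 to compound 4 (the limit leaves the size open). For compound 4 the estimated value is 14 mL.min-1.g-1, with an expected range from 8 mL.min-1.g-1 to 30 mL.min-1.g-1.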

Compound 4, intrinsic clearance in microsomes: 29 mL.min-1.g-1
Compound 4: the middle estimate sits 2.1-fold (0.32 log units) below what was measured; measured number inside the range.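

In this assay, putting 3-hydroxybut-1-yn-1-yl in place of methoxy on this aromatic carbon, two atoms from the ring nitrogen, gives an at least 2.0-fold higher number from compound 3 to compound 4 (0.31 log units; beyond the scatter), so the position can respond to a change in the group it carries. Among the compounds shown here, compound 4 is also the only compound here with a clearance that is a number rather than a limit, which sets it apart from the others: the limit of < 14 mL.min-1.g-1 in this assay, at which 3 of the 4 values shown sit. The new group differs from methoxy in several ways at once, since it is a longer chain with a triple bond, a hydrogen-bond donor and a defined stereocentre, and this single step ties all of these together.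

The compounds shown leave open which of these features goes with the higher number, and how large the step really is, as its starting point is a limit. A plain ethynyl group, a saturated 3-hydroxybutyl chain and the mirror-image form of the 3-hydroxybut-1-yn-1-yl group would each separate one feature from the others in this same assay.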